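A 3,4-Dichlorophenyl Group Enters Compound 3

A few compounds are considered here, and "the series" means these few. Any claim that something is new, unique, unknown or untested is made for them only; others in the source may bear on it.

Compound 1 `O=C(CCCCC1CCSS1)NCc1cn(CCCOc2ccc3ccc(=O)oc3c2)nn1`: 37.2%
Compound 2 `CCOC(=O)c1cc2ccc(OCCCn3cc(CNC(=O)CCCCC4CCSS4)nn3)cc2oc1=O`: 28.3%
Compound 3 `O=C(CCCCC1CCSS1)NCc1cn(CCCCOc2ccc3ccc(=O)oc3c2)nn1`: 45.9%

In a functional assay on PC-12 cells (Rattus norvegicus) for cytotoxicity, read by MTT assay, with stated times of 3 h and 2 h, tested at 1 uM (a lower number here means a weaker effect, a higher number a stronger effect of the compound at the concentration tested), compound 3 gives the highest of the three numbers; the nearest is compound 1, a step lower that is within the scatter, and the furthest is compound 2, a step lower that lies beyond the scatter. Compound 4 `O=C(CCCCC1CCSS1)NCc1cn(CCCCOc2ccc3cc(-c4ccc(Cl)c(Cl)c4)c(=O)oc3c2)nn1` differs from compound 3 in one place: 3,4-dichlorophenyl in place of hydrogen on an aromatic carbon. Within the data shown here, only one measured step changes a hydrogen on an aromatic carbon of the shared core, a number 8.9 percentage points lower from compound 1 to compound 2 (within the scatter), and that step stayed within the scatter. The step expected in this assay is therefore none beyond the scatter, estimated as a number 2.1 percentage points higher from compound 3 to compound 4 (within the scatter). Compound 4 is accordingly expected to give 48%, in a range from 30% to 66%.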

Compound 4, a percentage reported as activity, at one concentration (the size of the read-out at that concentration, not a potency): 49.3%
For compound 4 the middle estimate is 1.3 percentage points below the measured one, and the stated range covers the measured number.
By their numbers in this assay, from the lowest: compounds 2, 1, 3 and 4 (each within the scatter of the next, the first and the last beyond it).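

In this assay, the aromatic carbon two atoms from the ring oxygen accepts 3,4-dichlorophenyl, with its 8 heavy atoms and aromatic ring, with a number 3.4 percentage points higher from compound 3 to compound 4 (within the scatter). Among these compounds, the earlier step at a hydrogen on an aromatic carbon, a number 8.9 percentage points lower from compound 1 to compound 2 (within the scatter), involved ethoxycarbonyl, so this is the first such step to bring in an aromatic ring, and it also stays within the scatter. No measurement available here explains this result. On these data alone, whether an amine or a carboxylic acid at this position would move the number beyond the scatter remains open. So does the size of the step when 3,4-dichlorophenyl enters the core of compound 1.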